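The source may hold more compounds than are shown below. What is called first, only, known or untested is meant among the compounds shown, and "the series" means these compounds.

compound 1 `CCCCOC(=O)CN(c1ccccc1)[C@H]1c2cc(C#N)ccc2OC(C)(C)[C@@H]1O` - 27000 nM
compound 2 `CC1(C)Oc2ccc(C#N)cc2[C@H](N(Cc2ccco2)c2ccccc2)[C@H]1O` - 12000 nM

Going by the values given here, in a functional assay (aorta) with Rattus norvegicus as the target (a higher number here means a weaker inhibitor, a lower number a stronger inhibitor), compound 2 gives 12000 nM, the lower of the two numbers so far. The next compound, compound 3 `CC1(C)Oc2ccc(C#N)cc2[C@H](N(Cc2ncc[nH]2)c2ccccc2)[C@H]1O`, keeps the shared core and changes one group: 1H-imidazol-2-yl in place of furan-2-yl on a saturated chain carbon bound to a nitrogen on an aromatic ring. Put simply, 1H-imidazol-2-yl stands in place of furan-2-yl on a saturated chain carbon bound to a nitrogen on an aromatic ring. Among the compounds with values here, only one measured step touches that place: a 2.3-fold lower number from compound 1 to compound 2 (0.35 log units; beyond the scatter), with furan-2-yl replacing butoxycarbonyl. Within the data shown here, that step was modest, and no measurement yet covers 1H-imidazol-2-yl here. From the compounds shown here alone, a large move in this assay is therefore not expected, and the direction remains open. The expected change is a 1.2-fold higher number from compound 2 to compound 3 (0.07 log units; within the scatter), which would stay within the scatter. For compound 3 the estimate is 14000 nM, with an expected range from 4000 nM to 45000 nM.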

Compound 3, half-maximal inhibitory concentration: > 30000 nM
Compound 3 ended at the assay's limit (the forecaster's own chance of this, stated with the estimate: 25%); at least 2.1-fold (0.33 log units) between middle value and limit.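

Compound 3 gives a limit of the assay rather than a number in this assay: the limit of > 30000 nM in this assay, at which 1 of the 3 values shown sits. Even so, the exchange at the saturated chain carbon bound to a nitrogen on an aromatic ring can be read as an at least 2.5-fold higher number from compound 2 to compound 3 (0.39 log units; beyond the scatter), which shows that swapping one five-membered aromatic ring for another of 5 heavy atoms, with 1 hydrogen-bond donor entering, is enough to move the number beyond the scatter, and that in the upward direction. Against the butoxycarbonyl group the reading is an at least 1.1-fold higher number from compound 1 to compound 3 (0.04 log units; that floor lies within the scatter), a floor that does not separate those two compounds on its own.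

The compounds shown leave open how far compound 3 lies past its limit, and so the true size of both steps. They also leave open how a phenyl, a thiophen-2-yl or a 1-methyl-1H-imidazol-2-yl group would read at this place, so which difference between furan-2-yl and 1H-imidazol-2-yl carries the change remains unsettled.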